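The source may report more compounds than this note shows. Statements on the series, on what has been measured and on what is new or still open speak of the compounds shown alone.

Measured so far in a functional assay, with a stated time of 240 min, tested at 50 uM; a higher number here means a stronger effect of the compound at the concentration tested, a lower number a weaker effect:
compound 1 `COc1ccc2nc(/C=C/c3ccc(O)cc3)c(=O)n(CC(=O)O)c2c1`: 34.3%
compound 2 `COc1ccc2nc(/C=C/c3ccc(O)c(OC)c3)c(=O)n(CC(=O)O)c2c1`: 65.9%
compound 3 `COc1ccc2c(c1)nc(/C=C/c1ccc(O)cc1)c(=O)n2CC(=O)O`: 27.6%

Compound 4 `COc1ccc2c(c1)nc(/C=C/c1ccc(O)c(OC)c1)c(=O)n2CC(=O)O` awaits measurement in this assay.

Compound 1 and compound 2 differ by methoxy in place of hydrogen on an aromatic carbon; that change made a number 31.6 percentage points higher from compound 1 to compound 2 (beyond the scatter). Compound 4 stands to compound 3 exactly as compound 2 stands to compound 1: methoxy in place of hydrogen on an aromatic carbon. The surroundings of the entering group read the same in both pairs, so this is the same change on a second core. How the core of compound 3 differs from that of compound 1 is not broken down here; in this assay the values of compound 1 and compound 3 lie within the scatter of each other, so the two cores look alike as far as the data reach. Resting on that single measured instance, a number 31.6 percentage points higher from compound 1 to compound 2 (beyond the scatter), the step expected on the second core is a number 26.4 percentage points higher from compound 3 to compound 4 (beyond the scatter), kept a little more modest since only one example supports it. Compound 4 is expected to give about 54% in this assay, with a plausible span from 38% to 70%.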

Compound 4, a percentage reported as activity, at one concentration (the size of the read-out at that concentration, not a potency): 61.4%
For compound 4 the middle estimate is 7.4 percentage points below the measured one; low and high end bracket the measured number.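

In this assay, replacing 4-hydroxyphenyl with 4-hydroxy-3-methoxyphenyl on the second core gives a number 33.8 percentage points higher from compound 3 to compound 4 (beyond the scatter). Methoxy in place of hydrogen thus carries over between these two cores with a similar step: the same change on two cores in this assay, a number 31.6 percentage points higher (beyond the scatter) from compound 1 to compound 2 and a number 33.8 percentage points higher (beyond the scatter) from compound 3 to compound 4, 2.2 percentage points apart, within the scatter of two such steps. This rests on just two matched pairs at one tested concentration, and it shows neither why the step arises nor whether it would hold on any further core.

Still open, on these data alone, is whether the rise is specific to methoxy or would also appear with ethoxy, a longer alkoxy chain, fluorine or an amine on the same aromatic carbon. Also open, as far as these compounds go, is whether methoxy elsewhere on that ring would give a similar step.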